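The source may report more compounds than this note shows. Statements on the series, on what has been measured and on what is new or still open speak of the compounds shown alone.

Working notes on the series. The shared core carries a substituted benzyl on one ring and an aryl on another, and both ends vary. Compound 1 `COc1cc(Cn2cc(CNC(=O)c3cn(-c4ccccc4)nc3-c3ccccc3)nn2)cc(OC)c1OC` bears a trimethoxybenzyl and an unsubstituted phenyl. In a functional assay on HeLa cells (Homo sapiens) for antiproliferative activity, read by sulforhodamine B assay, with a stated time of 48 h (a lower number here means a stronger inhibitor of growth, a higher number a weaker inhibitor of growth), compound 1 gives only a limit, > 100000 nM. That reading sits at the limit of > 100000 nM in this assay, at which 1 of the 2 values shown sits. Within the data shown here, compound 2 `COc1ccc(-c2nn(-c3ccccc3)cc2C(=O)NCc2cn(Cc3ccc(OC)c(OC)c3)nn2)cc1` carries a dimethoxybenzyl together with a methoxyphenyl; in this assay compound 2 gives 800 nM, the only plain number in the set. Among the measured compounds shown here, compound 1 and compound 2 differ in two places, so their two values show no single step, one being a limit and one a number. Compound 3 `COc1ccc(-c2nn(-c3ccccc3)cc2C(=O)NCc2cn(Cc3cc(OC)c(OC)c(OC)c3)nn2)cc1` combines the two features: methoxy in place of hydrogen on an aromatic carbon, so the benzyl becomes a trimethoxybenzyl while the methoxyphenyl of compound 2 is kept. For the measured compounds named here, no measured step isolates this change. The expectation for compound 3 is a step of a 1.9-fold higher number from compound 2 to compound 3 (0.27 log units; within the scatter), within the usual scatter, with a small loss somewhat more likely than a gain. Compound 3 is therefore estimated in this assay at 1500 nM, with a range from 300 nM to 20000 nM.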

Compound 3, concentration for 50% growth inhibition: 1700 nM
Compound 3: middle estimate off by 1.1-fold (0.05 log units), on the low side; the range from low to high includes it.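

In this assay, among these compounds, the third methoxy on the benzyl end, the change from 3,4-dimethoxyphenyl to 3,4,5-trimethoxyphenyl, gives a 2.1-fold higher number from compound 2 to compound 3 (0.33 log units; beyond the scatter), a modest loss and the first single-place reading at this end of the series. Among the compounds shown here, the same replacement of hydrogen by methoxy at the other end, on the aryl with the trimethoxybenzyl kept, gives an at least 58-fold lower number from compound 1 to compound 3 (1.76 log units; beyond the scatter), so in the one pair that isolates it the aryl methoxy separates a measurable number from no measurable number, and that step is much larger than the one on the benzyl end. The size of this larger step has only a bound, the reading of compound 1 being a limit of the assay: the limit of > 100000 nM in this assay, at which 1 of the 3 values shown sits.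

The compounds shown leave open whether the aryl step belongs to methoxy itself or would also appear with a hydroxyl, a chlorine or a longer ethoxy group. They also leave open whether the aryl methoxy carries the same weight with the dimethoxybenzyl, and whether a benzyl with no methoxy at all keeps any activity.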